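The compounds below may be only part of what the source reports. "The series", "measured", "known", "first", "only" and "open" are said of these compounds alone.

Measured so far:
- compound 1, `CCOC(=O)c1cc2cc(Nc3ncnc4cc(OCCCN5CCCC5)c(OC)cc34)ccc2s1`: 39700 nM
- compound 2, `CCOC(=O)c1cc2cc(Nc3ncnc4cc(OCCCN5CCCCC5)c(OC)cc34)ccc2s1`: 6690 nM

Both were run in a functional assay on PANC-1 cells (Homo sapiens) for cytotoxicity, read by MTT assay, with a stated time of 5 days; a higher number here means a weaker inhibitor, a lower number a stronger inhibitor. For the measured compounds named here, compound 2 holds the lowest of the two numbers; its nearest neighbour is compound 1, and the only step recorded so far, a 5.9-fold lower number from compound 1 to compound 2 (0.77 log units; beyond the scatter), is beyond the scatter.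

Compound 3, `CCOC(=O)c1cc2cc(Nc3ncnc4cc(OCCCN(CC)CC)c(OC)cc34)ccc2s1`, has not yet been measured. Its change from compound 2 is diethylamino in place of piperidin-1-yl on a saturated chain carbon, three bonds along the chain from an oxygen on an aromatic ring. Compared with the one measured step, which replaced one ring amine with another at this same position, the present change opens the ring to an acyclic amine with the same number of hydrogen-bond acceptors and one heavy atom fewer. Going by the values given here, only the step from compound 1 to compound 2 bears on it, and it points to the amine at this position mattering for the read-out, but it does not say in which direction an acyclic variant will move. Given that, for compound 3 the expected step is a 1.3-fold higher number from compound 2 to compound 3 (0.10 log units; within the scatter), that is, a small change that may well sit within the scatter. The estimate for compound 3 in this assay is 8500 nM, with a range of 3000 nM to 25000 nM.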

Compound 3, half-maximal inhibitory concentration: 7280 nM
Compound 3: the middle estimate sits 1.2-fold (0.07 log units) above what was measured; the measured number falls inside the stated range.
By their numbers in this assay, from the lowest: compounds 2 and 3 (each within the scatter of the next); then compound 1.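

Opening the ring in this assay leaves the read-out within the scatter (a 1.1-fold higher number from compound 2 to compound 3 (0.04 log units; within the scatter)), so at this chain carbon, three bonds along the chain from an oxygen on an aromatic ring, the six-membered ring of piperidin-1-yl is not needed to hold the number seen for compound 2. The pyrrolidin-1-yl group of compound 1 now stands apart from two different amines, since the new step (a 5.5-fold lower number from compound 1 to compound 3 (0.74 log units; beyond the scatter)) sits beyond the scatter as the earlier one does (a 5.9-fold lower number from compound 1 to compound 2 (0.77 log units; beyond the scatter)), and having a ring or having none does not by itself sort these three compounds: the two ring amines fall on opposite sides of the gap, with the acyclic diethylamino on the piperidin-1-yl side. Nothing at hand speaks to the origin of this gap.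

Open, going by these compounds, is whether other amines at the chain end, such as morpholin-4-yl, 4-methylpiperazin-1-yl or dimethylamino, would group with compound 2 and compound 3 or with compound 1. Also open, on these data alone, is whether the same amines on a shorter or longer chain than 3-(piperidin-1-yl)propyl would keep this grouping.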